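A few compounds are considered here, and "the series" means these few. Any claim that something is new, unique, unknown or untested is made for them only; others in the source may bear on it.

Measured compounds:
- compound 1, `O=[N+]([O-])c1ccc(O[C@H]2CCc3ccccc3[C@@H]2n2ccnc2)cc1`: 21.4 ug/mL
- compound 2, `O=[N+]([O-])c1ccc(O[C@H]2CCc3ccccc3[C@@H]2n2ccnc2)c(F)c1`: 32.1 ug/mL
- compound 3, `O=[N+]([O-])c1ccc(O[C@H]2CCCC[C@@H]2n2ccnc2)cc1`: 8.27 ug/mL

These three were tested in an ADME assay on J774.A1 cells (Mus musculus) for cytotoxicity, read by MTT assay; a higher number here means that more compound is tolerated, a lower number that less compound is tolerated. Compound 1 and compound 2 share one core, and compound 2 carries one change on it: fluoro in place of hydrogen on an aromatic carbon. That change made a 1.5-fold higher number from compound 1 to compound 2 (0.18 log units; within the scatter). Compound 3 is built on a different core, and the difference between the two cores is not broken down here; what the numbers show is that compound 3 gives the lowest value of the three.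

Compound 4, `O=[N+]([O-])c1ccc(O[C@H]2CCCC[C@@H]2n2ccnc2)c(F)c1`, has not yet been measured. It stands to compound 3 as compound 2 stands to compound 1, with the same change: fluoro in place of hydrogen on an aromatic carbon. The place where the fluoro enters is described in identical words for both pairs, so this is the same change, made a second time on the other core.

In this assay the step from compound 3 to compound 4 is expected to be a 1.3-fold higher number from compound 3 to compound 4 (0.12 log units; within the scatter), set beside the step already seen from compound 1 to compound 2, because a 1.5-fold higher number from compound 1 to compound 2 (0.18 log units; within the scatter) stayed within the scatter. On that basis compound 4 is estimated at 11 ug/mL, most likely between 6 ug/mL and 20 ug/mL.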

Compound 4, half-maximal cytotoxic concentration: 14.3 ug/mL
For compound 4 the middle estimate is 1.3-fold (0.11 log units) below the measured one; low and high end bracket the measured number.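

In this assay, fluoro in place of hydrogen on an aromatic carbon gives a 1.7-fold higher number from compound 3 to compound 4 (0.24 log units; within the scatter), so on this second core the step again stays inside the ordinary spread of repeated measurements. The step on the core of compound 1 and the step on the core of compound 3 agree in size, and the change therefore carries across these two cores without any visible difference: the same change on two cores in this assay, a 1.5-fold higher number (0.18 log units; within the scatter) from compound 1 to compound 2 and a 1.7-fold higher number (0.24 log units; within the scatter) from compound 3 to compound 4, 1.2-fold (0.06 log units) apart, within the scatter of two such steps. This does not show that fluoro truly alters how much compound the cells tolerate, since each step on its own is small enough to be scatter, and two cores cannot say how the change would behave on a third.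

The compounds shown carry only fluoro at this place, ortho to a large group and meta to a nitro group, so it remains open whether chloro, methoxy or a nitrile there would give a clearer step. Also open, from the compounds shown here alone, is how the numbers would move if an amine or a carboxylic acid stood where the nitro group sits.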